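Amide chain on the fluoroquinolone-free chromone core

This account rests on a few compounds, and the source may have more. Where it says the series, first, only, none or still open, it means among the compounds named here.

Compound 1, `Cc1c(F)c(N)c2c(=O)cc(-c3ccc(N)c(F)c3)oc2c1F`, gives 13 nM in a functional assay on MCF7 cells (Homo sapiens) for cytotoxicity, read by neutral red uptake, with a stated time of 3 days; on this read-out higher numbers stand for weaker inhibition and lower numbers for stronger inhibition.
Compound 2, `CN(C)c1c(F)c(N)c2c(=O)cc(-c3ccc(N)c(F)c3)oc2c1F`, gives 39 nM in this assay.
Compound 3, `CCCCCCCCCCCCCCCCCC(=O)OCc1c(F)c(N)c2c(=O)cc(-c3ccc(N)c(F)c3)oc2c1F`, reaches only a limit in this assay, > 10000 nM.

Among the two plain numbers, compound 2 stands highest, so it is the weaker of the measured pair, and the one measured step is a 3.0-fold higher number from compound 1 to compound 2 (0.48 log units; beyond the scatter). Compound 4 is `CCCCCC(=O)NCc1c(F)c(N)c2c(=O)cc(-c3ccc(N)c(F)c3)oc2c1F`. It differs from compound 2 in this way: ((pentylcarbonyl)amino)methyl in place of dimethylamino on an aromatic carbon. Among the compounds with values here, the only step with a number shows that swapping a small group at this carbon moves the read-out modestly. Compound 3, which carries a far longer chain on a methylene at the same carbon, sits at the limit of > 10000 nM in this assay, at which 1 of the 3 values shown sits. The entering group in compound 4 is larger than dimethylamino but much shorter than the chain of compound 3, so a clear loss in this assay is expected, though not to the limit. The expected step is a 7.7-fold higher number from compound 2 to compound 4 (0.89 log units; beyond the scatter). Compound 4 is therefore estimated at 300 nM, in the range 60 nM to 3000 nM.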

Compound 4, half-maximal inhibitory concentration: 340 nM
Compound 4: middle estimate off by 1.1-fold (0.05 log units), on the low side, and the stated range covers the measured number.
By their numbers in this assay, from the lowest: compound 1; then compound 2; then compound 4. At a limit, above all of these: compound 3.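

Putting ((pentylcarbonyl)amino)methyl on this aromatic carbon, ortho to two fluoro groups, gives an 8.7-fold higher number from compound 2 to compound 4 (0.94 log units; beyond the scatter) in this assay, yet the read-out stays a plain number. Adding (pentylcarbonyl)amino to the carbon of the original methyl group gives a 26-fold higher number from compound 1 to compound 4 (1.42 log units; beyond the scatter), so a chain joined through an amide costs clear strength in this read-out without reaching a limit. Compound 3, with its longer chain joined through an ester, gives only a limit, not a number: the limit of > 10000 nM in this assay, at which 1 of the 4 values shown sits.

Compound 3 differs from compound 4 in more than one place, so the compounds shown do not separate the length of the chain from the kind of link. An aminomethyl group, a short acetyl amide or a longer amide chain at this carbon would show how the read-out follows chain length.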